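Swapping a Cyclohexyl for a Pyridinylmethyl on the Pyrazole Nitrogen

This account rests on a few compounds, and the source may have more. Where it says the series, first, only, none or still open, it means among the compounds named here.

The study examines three measured compounds and one that has not been measured, all bearing the same trifluoromethoxyphenyl amine. Compound 1 `NC(=O)CCn1ccc2c(Nc3ccc(OC(F)(F)F)cc3)ncnc21`, compound 2 `FC(F)(F)Oc1ccc(Nc2ncnc3nn(C4CCCCC4)cc23)cc1` and compound 3 `CNC(=O)c1cccc(-c2cc(Nc3ccc(OC(F)(F)F)cc3)ncn2)c1` were tested in an ADME assay on BaF3 cells (Mus musculus) for cytotoxicity; a higher number here means that more compound is needed for the effect, a lower number that less compound is needed. Compound 1 reaches only the limit of the assay, at > 10000 nM. Compound 3 likewise reaches only the limit, at > 10000 nM. Compound 2 stands at the same place: its value is a limit rather than a number, at > 10000 nM. For the measured compounds named here, since all three values are limits, no ordering among them can be read, and there is the limit of > 10000 nM in this assay, at which 3 of the 3 values shown sit, so that no step between measured compounds is available.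

Compound 4 `FC(F)(F)Oc1ccc(Nc2ncnc3nn(Cc4cccnc4)cc23)cc1` differs from compound 2 in one place: (pyridin-3-yl)methyl in place of cyclohexyl on an aromatic nitrogen, in words, (pyridin-3-yl)methyl in place of cyclohexyl on an aromatic nitrogen. With every shown value sitting at the limit, no direction can be taken from the data, and the expectation is that the step in this assay from compound 2 to compound 4 is none beyond the scatter, a step that the limit leaves unreadable from compound 2 to compound 4. Compound 4 is therefore estimated to give 15000 nM in this assay, within a range from 5000 nM to 50000 nM, most likely reported again only as a limit.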

Compound 4, half-maximal effective concentration: > 10000 nM
Compound 4: a limit, no number; the forecaster's own chance of this, stated with the estimate: 85%; the middle value is on the limit's open side.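

No step can be read between compound 2 and compound 4 in this assay because both values are limits: the limit of > 10000 nM in this assay, at which 4 of the 4 values shown sit.

The compounds shown leave open whether any of them would give a measurable half-maximal effective concentration in this assay and whether (pyridin-3-yl)methyl in place of cyclohexyl changes that concentration at all.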